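Compound 1 to compound 4: pyrimidin-2-yl in place of isopropyl

The source may hold more compounds than are shown below. What is called first, only, known or untested is meant among the compounds shown, and "the series" means these compounds.

Among the measured compounds shown here, in an ADME assay on microsomes from liver (Homo sapiens) for metabolic stability, read by LC-MS, with a stated time of 10 min (a higher number here means that more of the compound is left, a lower number that less of the compound is left), compound 1 `CC(C)N1CCN(c2cccc3c2C[C@H](CN(C)[C@H]2CCCc4cccnc42)NC3)CC1` gives 56.6%, the highest of the three numbers so far. Compound 2 `CN(C[C@H]1Cc2c(cccc2N2CCN3CCC[C@H]3C2)CN1)[C@H]1CCCc2cccnc21` gives 36.6%, and compound 3 `C[C@@H]1CN(c2cccc3c2C[C@H](CN(C)[C@H]2CCCc4cccnc42)NC3)C[C@H](C)N1C` gives 24.6%. The step under consideration leads to compound 4 `CN(C[C@H]1Cc2c(cccc2N2CCN(c3ncccn3)CC2)CN1)[C@H]1CCCc2cccnc21`: pyrimidin-2-yl in place of isopropyl on an amine nitrogen in a ring.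

Two measured steps start from compound 1 and both change the group on an aromatic carbon: a number 20 percentage points lower from compound 1 to compound 2 (beyond the scatter) is modest and a number 32 percentage points lower from compound 1 to compound 3 (beyond the scatter) is large, each beyond the scatter. Neither introduces an aromatic ring, so they are only an indirect guide. They also show just two departures from a single compound that already stands highest. A downward step of similar size is therefore expected, with wide uncertainty. The estimated step is a number 21.6 percentage points lower from compound 1 to compound 4 (beyond the scatter). For compound 4 the estimated value is 35%, with an expected range of 15% to 58%.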

Compound 4, percent of the compound remaining: 35.5%
Beside the measured number, compound 4's estimate is 0.5 percentage points below it; measured number inside the range.
By their numbers in this assay, from the lowest: compound 3; then compounds 4 and 2 (each within the scatter of the next); then compound 1.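

In this assay there is a number 21.1 percentage points lower from compound 1 to compound 4 (beyond the scatter) with pyrimidin-2-yl in place of isopropyl on the amine nitrogen in the ring, so the group on this nitrogen alone moves the number beyond the scatter. The earlier steps shown here replaced the whole group on the aromatic carbon, whereas here the six-membered ring with two nitrogens stays and only its substituent changes. Compound 1, with isopropyl, remains the highest of the four compounds. Nothing measured here accounts for the step.

Open, as far as these compounds go, is whether the step goes with the aromatic ring itself or with its two ring nitrogens, a question that phenyl on the same nitrogen would address. Also open, from the compounds shown here alone, is whether a small non-aromatic group on this nitrogen, such as cyclopropyl, would stay with compound 1 or fall with compound 4.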